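Methoxy for fluoro on a benzylic urea

This account rests on a few compounds, and the source may have more. Where it says the series, first, only, none or still open, it means among the compounds named here.

Among the measured compounds shown here, compound 1 `O=C(NCc1ccccc1F)N1C(=O)c2ccccc2S1(=O)=O` is the only member of this small set with an actual number in a physicochemical assay for pharmacokinetics; on this read-out lower numbers stand for a shorter-lived compound and higher numbers for a longer-lived compound: compound 1 gives 0.598 h. The two other compounds sit at the edges of the range of this assay. Compound 2 `O=C(OCc1ccccc1)N1C(=O)c2ccccc2S1(=O)=O` reaches only a limit of this assay, < 0.0167 h, which is the limit of < 0.0167 h in this assay, at which 1 of the 3 values shown sits. Compound 3 `O=C(c1ccccc1)N1Cc2ccccc2C1=O` likewise reaches only a limit, > 166 h, which is the limit of > 166 h in this assay, at which 1 of the 3 values shown sits. For the measured compounds named here, no step between measured compounds that differ in one place is available, so nothing measured says how a single substituent change moves this read-out.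

Compound 4 `COc1ccccc1CNC(=O)N1C(=O)c2ccccc2S1(=O)=O` differs from compound 1 in one place: methoxy in place of fluoro on an aromatic carbon. The shared core and the urea linkage of compound 1 are kept unchanged. Going by the values given here, with no measured step of this kind to lean on, the expected step from compound 1 to compound 4 in this assay is small, a 1.2-fold higher number from compound 1 to compound 4 (0.07 log units; within the scatter), and within the usual scatter of repeated measurements. Compound 4 is therefore estimated at 0.7 h, with a range from 0.3 h to 1.8 h.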

Compound 4, half-life: 1.12 h
For compound 4 the middle estimate is 1.6-fold (0.20 log units) below the measured one, and the stated range covers the measured number.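

In this assay, the set now holds its first step between compounds that differ in one place: a 1.9-fold higher number from compound 1 to compound 4 (0.27 log units; within the scatter) for methoxy in place of fluoro. Among the compounds shown here, this step lies within the scatter, so at this place, on an aromatic carbon ortho to a large group, the exchange of 2-fluorophenyl for 2-methoxyphenyl gives a half-life that cannot be told apart from the earlier one, something the earlier compounds could not show. No measurement shown gives a cause for this step.

As far as these compounds go, whether an amine, a carboxylic acid or a longer chain at this place would also stay within the scatter remains open. Also open, from the compounds shown here alone, is whether the same exchange would read the same way with a linkage other than the urea.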